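Removing one methoxy on the chalcone series: working notes

The source may report more compounds than this note shows. Statements on the series, on what has been measured and on what is new or still open speak of the compounds shown alone.

Measured in a functional assay on MCF7 cells (Homo sapiens) for cytotoxicity, read by sulforhodamine B assay, with a stated time of 48 h; on this read-out lower numbers stand for stronger inhibition and higher numbers for weaker inhibition:
compound 1 `COc1ccc(/C=C/C(=O)c2cccc(-c3cccc(F)c3)c2)cc1`: 3080 nM
compound 2 `COc1cc(/C=C/C(=O)c2ccc(N)c(-c3ccc(F)cc3)c2)cc(OC)c1OC`: 9030 nM
compound 3 `COc1ccc(/C=C/C(=O)c2cccc(-c3cccc(F)c3)c2)cc1OC`: 4620 nM

Compound 3 differs from compound 1 by hydrogen in place of methoxy on an aromatic carbon; the step is a 1.5-fold lower number from compound 3 to compound 1 (0.18 log units; within the scatter). Compound 2 and compound 3 differ in more than one place; the difference between the two cores is not broken down here. Compound 2 stands beyond the scatter only against compound 1. Compound 4 `COc1ccc(/C=C/C(=O)c2ccc(N)c(-c3ccc(F)cc3)c2)cc1OC` is not yet measured and differs from compound 2 by hydrogen in place of methoxy on an aromatic carbon. The place is not the same word for word: here the carbon is also meta to a methoxy group, so this is the same kind of change, not the same. The step from compound 2 is expected to be a 1.4-fold lower number from compound 2 to compound 4 (0.14 log units; within the scatter), resting on the earlier step of a 1.5-fold lower number from compound 3 to compound 1 (0.18 log units; within the scatter). Compound 4 is estimated at 6500 nM in this assay, between 3000 nM and 14000 nM.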

Compound 4, half-maximal inhibitory concentration: 15000 nM
Beside the measured number, compound 4's estimate is 2.3-fold (0.36 log units) below it; the measured number lies above the stated range.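

On the core of compound 2, hydrogen in place of methoxy on an aromatic carbon gives a 1.7-fold higher number from compound 2 to compound 4 (0.22 log units; within the scatter) in this assay on this core, so no direction can be read from this step alone. Set beside the same change on the core of compound 1, the two steps do not stand apart: the same change on two cores in this assay, a 1.5-fold lower number (0.18 log units; within the scatter) from compound 3 to compound 1 and a 1.7-fold higher number (0.22 log units; within the scatter) from compound 2 to compound 4, 2.5-fold (0.40 log units) apart, within the scatter of two such steps. This shows that the change stays within the scatter on both cores, but it rests on one pair per core and does not show that the change would behave alike on any further core.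

From the compounds shown here alone, whether a hydroxyl group or an ethoxy group on that aromatic carbon would read differently stays open. So does whether the change would step beyond the scatter on a core other than these two.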